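This account rests on a few compounds, and the source may have more. Where it says the series, first, only, none or still open, it means among the compounds named here.

Measured so far in an assay on microsomes from liver for inhibition of acyl-CoA desaturase 1 (Rattus norvegicus); on this read-out higher numbers stand for weaker inhibition and lower numbers for stronger inhibition:

Compound 1 `Brc1ccccc1OC1CCN(c2ccc(-n3ccnc3)nn2)CC1`: compound 1 gives 5 nM.
Compound 2 `FC(F)(F)c1ccccc1OC1CCN(c2ccc(-n3ccnc3)nn2)CC1`: compound 2 gives 4 nM.
Compound 3 `Brc1cccc(OC2CCN(c3ccc(-n4ccnc4)nn3)CC2)c1`: compound 3 gives 23 nM.

Compounds 1 and 3 carry the same atoms joined differently; the difference between them is 3-bromophenyl in place of 2-bromophenyl on an oxygen on a saturated carbon, and it brings a 4.6-fold higher number from compound 1 to compound 3 (0.66 log units; beyond the scatter). Compound 4 `FC(F)(F)c1cccc(OC2CCN(c3ccc(-n4ccnc4)nn3)CC2)c1` is not yet measured in this assay.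

The change from compound 3 to compound 4 is trifluoromethyl in place of bromo on an aromatic carbon. The same change has been made once before, from compound 1 to compound 2, where it is trifluoromethyl in place of bromo on an aromatic carbon and gives a 1.3-fold lower number from compound 1 to compound 2 (0.10 log units; within the scatter). The two occurrences are the same kind of change rather than the same change: in compound 2 the trifluoromethyl sits ortho to a large group, in compound 4 it sits meta to a large group.

On the strength of that earlier step from compound 1 to compound 2, compound 4 is expected to move by about a 1.3-fold lower number from compound 3 to compound 4 (0.11 log units; within the scatter) relative to compound 3, because a 1.3-fold lower number from compound 1 to compound 2 (0.10 log units; within the scatter) was small. Compound 4 is therefore estimated at 18 nM in this assay, with a likely range from 8 nM to 40 nM.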

Compound 4, half-maximal inhibitory concentration: 19 nM
For compound 4 the middle estimate is 1.1-fold (0.02 log units) below the measured one; measured number inside the range.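

In this assay, trifluoromethyl in place of bromo gives a 1.2-fold lower number from compound 3 to compound 4 (0.08 log units; within the scatter), and set beside the earlier case the two steps agree: the same change on two cores in this assay, a 1.3-fold lower number (0.10 log units; within the scatter) from compound 1 to compound 2 and a 1.2-fold lower number (0.08 log units; within the scatter) from compound 3 to compound 4, 1.0-fold (0.01 log units) apart, within the scatter of two such steps. In these two pairs, then, the exchange of bromo for trifluoromethyl reads the same on the 2-bromophenyl and the 3-bromophenyl compounds, with neither step beyond the scatter, so the earlier step served as a fair guide when carried to the other core. Going by these compounds alone, this does not show that the two groups are interchangeable across the series, since it rests on only two pairs that share everything except where the substituent sits, and it gives no reason why the steps agree.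

The compounds shown leave open whether the same agreement would hold for other groups in these places, such as a nitrile, a methoxy group, an amine or a carboxylic acid. They also leave open whether the exchange would still carry over if the rest of the shared core were altered.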